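Replacing 4-methoxyphenyl with 2,4,6-trimethylphenyl in compound 3

The source may report more compounds than this note shows. Statements on the series, on what has been measured and on what is new or still open speak of the compounds shown alone.

Two related compounds have so far been read in a functional assay on HepG2 cells (Homo sapiens) for inhibition, read by MTT assay, with a stated time of 48 h; on this read-out higher numbers stand for weaker inhibition and lower numbers for stronger inhibition. Compound 1 (`COc1ccc(/C=C2\SC(=O)N(CCNC(=O)Nc3c(C)n(C)n(-c4ccccc4)c3=O)C2=O)cc1`) gives 8370 nM, and compound 2 (`COc1ccc(/C=C2\SC(=O)N(CC(=O)Nc3c(C)n(C)n(-c4ccccc4)c3=O)C2=O)cc1`) gives 68500 nM. Compound 2 therefore holds the higher of the two numbers, meaning the weaker inhibition, and its gap to compound 1 lies beyond the scatter.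

Compound 3 (`Cc1cc(C)c(/C=C2\SC(=O)N(CC(=O)Nc3c(C)n(C)n(-c4ccccc4)c3=O)C2=O)c(C)c1`) departs from compound 2 in one place: 2,4,6-trimethylphenyl in place of 4-methoxyphenyl on a double-bonded chain carbon bound to a double-bonded ring carbon. Here 2,4,6-trimethylphenyl stands in place of 4-methoxyphenyl on a double-bonded chain carbon bound to a double-bonded ring carbon. Among the compounds with values here, no measured pair isolates this exchange, so the only direct anchor is compound 2 at 68500 nM, and the direction of any change is poorly supported. The estimated change, a 1.5-fold lower number from compound 2 to compound 3 (0.18 log units; within the scatter), is expected to be a small drop in the number that stays within the scatter in this assay. For compound 3 the expected value is 45000 nM, with an estimated range of 18000 nM to 110000 nM.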

Compound 3, half-maximal inhibitory concentration: 63500 nM
The estimate for compound 3 lay 1.4-fold (0.15 log units) below the measured number; low and high end bracket the measured number.
By their numbers in this assay, from the lowest: compound 1; then compounds 3 and 2 (each within the scatter of the next).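

In this assay, within the data shown here, placing 2,4,6-trimethylphenyl in place of 4-methoxyphenyl on a double-bonded chain carbon bound to a double-bonded ring carbon gives a 1.1-fold lower number from compound 2 to compound 3 (0.03 log units; within the scatter), the first reading of this position. The step stays within the scatter even though the exchange removes the oxygen and takes the group from 1 hydrogen-bond acceptor to 0, so for this pair neither the methoxy group nor that acceptor is needed to hold the read-out where compound 2 stands. No measurement on hand explains why the read-out stays within the scatter across this exchange.

Two aryl groups on a single background cannot show whether this position is insensitive in general, and a phenyl ring bearing a carboxylic acid or an amine could still separate from compound 2. Among these compounds, it also remains open whether the same exchange would stay within the scatter on the longer urea-bearing chain of compound 1, the only compound here with a urea in that chain.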